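A few compounds are considered here, and "the series" means these few. Any claim that something is new, unique, unknown or untested is made for them only; others in the source may bear on it.

Measured so far in a functional assay on HCT-15 cells (Homo sapiens) for antiproliferative activity, read by sulforhodamine B assay, with a stated time of 48 h, tested at 50 uM; a lower number here means less inhibition, a higher number more inhibition at the concentration tested (going by the name of the read-out):
- compound 1, `COc1cccc(C(=O)Oc2cc3c(cc2C)[C@@H](C(C)C)CC=C3C)c1`: "not active" (no number reported)
- compound 2, `CC1=CC[C@H](C(C)C)c2cc(C)c(OC(=O)Nc3ccccc3)cc21`: 92%
- compound 3, `CC1=CC[C@H](C(C)C)c2cc(C)c(OC(=O)c3ccc([N+](=O)[O-])cc3)cc21`: 67.8%

All three share one core, an ester or carbamate hanging off it, and differ only in the group on the carbonyl carbon. Compound 1 gives "not active" (no number reported) in this assay, with no number attached. Compound 2 gives 92%. Compound 3 gives 67.8%, the lower of the two reported numbers; the step of a number 24.2 percentage points lower from compound 2 to compound 3 (beyond the scatter) lies beyond the usual scatter and comes from the change of 4-nitrophenyl in place of anilino on the carbonyl carbon.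

Compound 4, `CC1=CC[C@H](C(C)C)c2cc(C)c(OC(=O)c3ccc(C(F)(F)F)cc3)cc21`, differs from compound 3 by trifluoromethyl in place of nitro on an aromatic carbon, on an aromatic carbon of a six-membered aromatic ring of carbon only, para to a large group. Among the compounds with values here, no measured step swaps one group for another on that ring, so the step from compound 2 to compound 3 bears on it only loosely: it shows that a change at this part of the molecule can move the read-out by a modest amount. With no closer guide, the expectation is a change of a number 9.8 percentage points lower from compound 3 to compound 4 (within the scatter), small and possibly within the scatter, in this assay. Compound 4 is therefore estimated at 58%, with a range from 25% to 85%.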

Compound 4, a percentage reported as inhibition, at one concentration (the size of the read-out at that concentration, not a potency): 6.4%
Beside the measured number, compound 4's estimate is 51.6 percentage points above it; the whole stated range lies above it.
By their numbers in this assay, from the lowest: compound 4; then compound 3; then compound 2.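

The group on the aromatic ring, para to a large group, turns out to matter a great deal: in this assay, trifluoromethyl in place of nitro gives a number 61.4 percentage points lower from compound 3 to compound 4 (beyond the scatter) and so leaves compound 4 as the lowest of the numbered compounds. The earlier step of a number 24.2 percentage points lower from compound 2 to compound 3 (beyond the scatter) exchanged the whole group on the carbonyl carbon, yet this single change on the ring moves the read-out further. No measurement is on hand that would explain the drop.

The compounds shown leave open how an amine, a chlorine atom or a plain hydrogen at this same place would read, so it remains unclear whether nitro raises the number or trifluoromethyl lowers it. They also leave open whether the same swap would move the read-out as far with the anilino carbamate of compound 2.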